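Swapping a Carbamate Tail for a Pyrrolidine-Bearing Amide

The compounds below may be only part of what the source reports. "The series", "measured", "known", "first", "only" and "open" are said of these compounds alone.

Of the compounds shown here, two sharing one core have been tested in a functional assay on the whole organism for inhibition of sodium-dependent dopamine transporter (Mus musculus); a higher number here means that more compound is needed for the effect, a lower number that less compound is needed. Compound 1 `CN1Cc2c(N)cccc2C(c2ccc(Cl)cc2)C1` gives 1.5 mg/kg. Compound 2 `CN1Cc2c(NC(=O)OCc3ccccc3)cccc2C(c2ccccc2)C1` gives 25 mg/kg, the highest of the two numbers; its nearest neighbour, compound 1, sits far lower, well beyond the usual scatter. The two differ in more than one place, so their gap cannot be tied to a single change.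

Compound 3 `CN1Cc2c(NC(=O)CN3CCCC3)cccc2C(c2ccccc2)C1` is not yet measured. It differs from compound 2 in one place: (pyrrolidin-1-yl)methyl in place of benzyloxy on a carbonyl carbon. Among the measured compounds shown here, no measured pair shows this change, so its effect in this assay is unknown. Given that compound 2 gives 25 mg/kg, a moderate shift toward a lower number is expected for compound 3, though a result within the scatter would not surprise. The step of a 2.1-fold lower number from compound 2 to compound 3 (0.32 log units; beyond the scatter) is an estimate only. Compound 3 is expected to give about 12 mg/kg, with a likely range from 3 mg/kg to 50 mg/kg.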

Compound 3, dose for half-maximal effect: 45 mg/kg
For compound 3 the middle estimate is 3.8-fold (0.57 log units) below the measured one; the measured number falls inside the stated range.
By their numbers in this assay, from the lowest: compound 1; then compounds 2 and 3 (each within the scatter of the next).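

At this position, on a carbonyl carbon whose other neighbour is an amide-type nitrogen, replacing benzyloxy with (pyrrolidin-1-yl)methyl gives a 1.8-fold higher number from compound 2 to compound 3 (0.26 log units; within the scatter) in this assay. This exchanges a six-membered aromatic ring of carbon only for a five-membered non-aromatic ring with one hetero atom, yet the two numbers cannot be told apart, so this read-out shows no clear effect of the change. No other measurement here helps to interpret this result.

From the compounds shown here alone, it remains open whether a smaller group such as methyl, or a morpholin-4-ylmethyl group, on this carbonyl carbon would move the number beyond the scatter. Also open, going by these compounds, is how the core of compounds 2 and 3 would read with a plain amine in place of the acylated nitrogen.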